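Quinolin-5-yl in place of pyridin-4-yl: notes on compound 3

This account rests on a few compounds, and the source may have more. Where it says the series, first, only, none or still open, it means among the compounds named here.

Of the compounds shown here, two sharing one core have been measured in a physicochemical assay for solubility, in phosphate buffer, at pH 7.4; a higher number here means a more soluble compound, a lower number a less soluble compound. Compound 1 `c1ccc(-c2nccnc2OC2CN(c3ccc4ccccc4n3)C2)cc1` gives < 1000 nM, which is a limit of the assay and not a number. For the measured compounds named here, compound 2 `c1ccc2nc(N3CC(Oc4nccnc4-c4ccncc4)C3)ccc2c1` gives 56000 nM, the only actual number so far.

Compound 3 `c1ccc2nc(N3CC(Oc4nccnc4-c4cccc5ncccc45)C3)ccc2c1` carries quinolin-5-yl in place of pyridin-4-yl on an aromatic carbon. Going by the values given here, one measured step bears on this position, with pyridin-4-yl in place of phenyl: an at least 56-fold higher number from compound 1 to compound 2 (1.74 log units; beyond the scatter). This step is large and beyond the scatter, and one end of it rests on (the limit of < 1000 nM in this assay, at which 1 of the 2 values shown sits). Compound 3 keeps an aromatic ring with a hetero atom at this place but adds a six-membered aromatic ring of carbon only, the ring type found in compound 1 at < 1000 nM. A result between the two measured compounds therefore seems likely, with a lower number than for compound 2. The estimated change is a 9.3-fold lower number from compound 2 to compound 3 (0.97 log units; beyond the scatter), beyond the scatter. For compound 3 the expected value in this assay is 6000 nM, with an estimated range of 1500 nM to 25000 nM.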

Compound 3, solubility: 47000 nM
Estimate against measurement, compound 3: 7.8-fold (0.89 log units) below; measured number above the stated range.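

Within this assay, the aromatic carbon next to the ring nitrogen accepts quinolin-5-yl as readily as pyridin-4-yl: the step is a 1.2-fold lower number from compound 2 to compound 3 (0.08 log units; within the scatter), so the added six-membered aromatic ring of carbon only leaves the read-out within the scatter. The comparison with phenyl also holds for the larger group, at an at least 47-fold higher number from compound 1 to compound 3 (1.67 log units; beyond the scatter), which shows that the earlier large step is not confined to pyridin-4-yl and that a carbon-only ring within the group does not by itself bring the number back towards that of compound 1. Compound 1 stands at < 1000 nM, which is a limit of the assay and not a number, so both large steps from it are known only from one side: the limit of < 1000 nM in this assay, at which 1 of the 3 values shown sits.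

Still open, going by these compounds, is whether the ring nitrogen of the group is what separates these compounds from compound 1, a question that naphthalen-1-yl, with both rings of carbon only, would address directly. Also open, on these data alone, is how far the read-out depends on an aromatic group at this place at all, as opposed to a saturated amine such as morpholin-4-yl or a short alkyl chain.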